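This account rests on a few compounds, and the source may have more. Where it says the series, first, only, none or still open, it means among the compounds named here.

Working notes on the series. Compound 1 `O=C(Nc1cccc(-n2cc(-c3ccncc3)c(-c3ccc(Cl)c(O)c3)n2)c1)Nc1ccc(Cl)c(Cl)c1` carries a 4-chloro-3-hydroxyphenyl group on the shared core together with a dichlorophenyl urea. In a functional assay on MCF7 cells (Homo sapiens) for inhibition, read by sulforhodamine B assay, with a stated time of 48 h (on this read-out higher numbers stand for weaker inhibition of growth and lower numbers for stronger inhibition of growth), compound 1 returns only a limit of the assay, > 32500 nM, and no number. Compound 2 `COc1cc(-c2nn(-c3cccc(NC(=O)Nc4ccc(Cl)c(C(F)(F)F)c4)c3)cc2-c2ccncc2)ccc1Cl` keeps the same core but carries a 4-chloro-3-methoxyphenyl group and a chloro-trifluoromethylphenyl urea. In this assay compound 2 likewise returns only a limit, > 32500 nM, so its standing on the numbers shown is that of an inactive member at the limit; both values shown sit at that limit (the limit of > 32500 nM in this assay, at which 2 of the 2 values shown sit), and no measured step between two compounds is available.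

Compound 3 `O=C(Nc1cccc(-n2cc(-c3ccncc3)c(-c3ccc(Cl)c(O)c3)n2)c1)Nc1ccc(Cl)c(C(F)(F)F)c1` is compound 2 with the change (hydrogen in place of methyl on an oxygen on an aromatic ring), hydrogen in place of methyl on an oxygen on an aromatic ring. For the measured compounds named here, no step between measured compounds covers this change. Compound 3 is expected to stay at the limit, an expected step that the limit leaves unreadable from compound 2 to compound 3 in this assay, none beyond the scatter. The estimate for compound 3 is 40000 nM, between 15000 nM and 100000 nM, most likely reported again only as a limit.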

Compound 3, concentration for total growth inhibition: > 32500 nM
Compound 3: only a limit was reported (the forecaster's own chance of this, stated with the estimate: 80%); the middle value is on the limit's open side.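

No step can be read from compound 2 to compound 3 or from compound 1 to compound 3, since all three compounds stand only as limits: the limit of > 32500 nM in this assay, at which 3 of the 3 values shown sit.

The compounds shown leave open whether methoxy to hydroxy, or chloro to trifluoromethyl, changes growth inhibition at all, and how any of these compounds would rank on a measured number.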